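Benzyl in place of phenyl on the amide of compound 1

A few compounds are considered here, and "the series" means these few. Any claim that something is new, unique, unknown or untested is made for them only; others in the source may bear on it.

Among the compounds with values here, compound 1 `CCSC(=S)SCC(=O)c1ccc(C(=O)Nc2ccccc2)cc1` is one of three compounds measured in an assay on HEK293 cells for inhibition of protein deacetylase HDAC6 (Homo sapiens); a higher number here means a weaker inhibitor, a lower number a stronger inhibitor. In this assay compound 1 gives 521 nM. Compound 2 `CCSC(=S)SCC(=O)c1ccc(NS(=O)(=O)c2ccccc2)cc1` gives 382 nM, a number that lies within the scatter of repeated measurements of the value of compound 1, so the two cannot be told apart. Compound 3 `CCSC(=S)SCC(=O)c1cccc(S(=O)(=O)N(C)c2ccc(OC)cc2)c1` gives 2040 nM, a higher number that lies beyond the scatter, so compound 3 is the weakest inhibitor of the three, and compound 1 stands together with compound 2 ahead of it.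

Compound 4 `CCSC(=S)SCC(=O)c1ccc(C(=O)NCc2ccccc2)cc1` differs from compound 1 in a single place: benzyl in place of phenyl on an amide-type nitrogen. Cut one bond further out, the same change reads anilino to benzylamino. Within the data shown here, no pair of measured compounds differs in just this way, so nothing measured shows what this change does to the number. Since the rest of the structure is untouched, the expected step from compound 1 to compound 4 is one that stays within the scatter, a 1.0-fold lower number from compound 1 to compound 4 (0.02 log units; within the scatter). Compound 4 is therefore expected to give about 500 nM, with a range from 200 nM to 1500 nM.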

Compound 4, half-maximal inhibitory concentration: 830 nM
Compound 4: middle estimate off by 1.7-fold (0.22 log units), on the low side; measured number inside the range.
By their numbers in this assay, from the lowest: compounds 2, 1 and 4 (each within the scatter of the next, the first and the last beyond it); then compound 3.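

Within the data shown here, the first pair of compounds that differ in a single place shows that, in this assay, benzyl in place of phenyl on the amide-type nitrogen gives a 1.6-fold higher number from compound 1 to compound 4 (0.20 log units; within the scatter). Moving from anilino to benzylamino therefore leaves the number within the scatter, so this change cannot be told apart from no change at all in this one pair. Nothing measured here explains this outcome.

The compounds shown leave open whether the number would move beyond the scatter with a longer chain such as phenethyl, with cyclohexyl in place of phenyl, or with a carboxylic acid or an amine on the benzyl ring. Among these compounds, they also leave open whether the same change would give a similar step on a different core, as only this single pair carries it.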